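The source may hold more compounds than are shown below. What is called first, only, known or untested is meant among the compounds shown, and "the series" means these compounds.

Working notes on the series in a physicochemical assay for solubility, measured as kinetic solubility, with a stated time of 15 h, at pH 7.4; on this read-out higher numbers stand for higher solubility and lower numbers for lower solubility. Compound 1 `OC[C@H]1O[C@H](Oc2ccc(-c3ccccc3Cl)cc2Cl)[C@@H](O)[C@@H](O)[C@@H]1O` gives 28 ug/mL, compound 2 `OC[C@H]1O[C@H](Oc2ccc(-c3ccc(Cl)cc3)cc2Cl)[C@@H](O)[C@@H](O)[C@@H]1O` gives 3.5 ug/mL, and compound 3 `OC[C@H]1O[C@H](Oc2ccc(-c3ccc(Cl)c(Cl)c3)cc2Cl)[C@@H](O)[C@@H](O)[C@@H]1O` gives 2.3 ug/mL. Compound 3 therefore sits at the low end of the three numbers, level with compound 2 within the scatter, as a 1.5-fold lower number from compound 2 to compound 3 (0.18 log units; within the scatter) shows. It lies far from compound 1, with a 12-fold lower number from compound 1 to compound 3 (1.09 log units; beyond the scatter).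

The next compound is compound 4 `O=[N+]([O-])c1cccc(-c2ccc(O[C@H]3O[C@H](CO)[C@@H](O)[C@H](O)[C@@H]3O)c(Cl)c2)c1`, which has 3-nitrophenyl in place of 3,4-dichlorophenyl on an aromatic carbon. For the measured compounds named here, no measured step introduces a nitro group, so there is no direct evidence for this change. The closest comparison is a 1.5-fold lower number from compound 2 to compound 3 (0.18 log units; within the scatter), a change on the same aryl ring that stays within the scatter. The larger steps, an 8.0-fold lower number from compound 1 to compound 2 (0.90 log units; beyond the scatter) and a 12-fold lower number from compound 1 to compound 3 (1.09 log units; beyond the scatter), both start from the 2-chlorophenyl group. Compound 4 does not carry that group, so neither step offers a direct precedent for a return towards the value of compound 1.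

A small step towards a higher number is expected, with little confidence in its direction. The expected change is a 2.0-fold higher number from compound 3 to compound 4 (0.29 log units; within the scatter). The estimated value for compound 4 is 4.5 ug/mL, with an expected range of 1.5 ug/mL to 13 ug/mL.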

Compound 4, solubility: 23 ug/mL
For compound 4 the middle estimate is 5.1-fold (0.71 log units) below the measured one; measured number above the stated range.
By their numbers in this assay, from the lowest: compounds 3 and 2 (each within the scatter of the next); then compounds 4 and 1 (each within the scatter of the next).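

In this assay, for the compounds shown here, the 2-chlorophenyl group is no longer the only aryl group on this aromatic carbon that goes with the higher numbers: 3-nitrophenyl gives a 10-fold higher number from compound 3 to compound 4 (1.00 log units; beyond the scatter) and a 6.6-fold higher number from compound 2 to compound 4 (0.82 log units; beyond the scatter) at the same place. The step of a 1.2-fold lower number from compound 1 to compound 4 (0.09 log units; within the scatter) leaves the two compounds level, so among these four compounds the low end holds only 4-chlorophenyl and 3,4-dichlorophenyl, while 2-chlorophenyl and 3-nitrophenyl stand together at the high end. No measurement given here accounts for the size of this change.

On these data alone, the step from 3,4-dichlorophenyl to 3-nitrophenyl removes two chloro groups and brings in a nitro group in a single change, so the share of each stays open, and it is equally open whether 3-chlorophenyl would sit with the high pair or the low pair. Whether other groups at this place, such as an amine or a carboxylic acid on the same phenyl ring, would stay level with compound 4 or fall towards compound 3 also cannot be told from these compounds.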